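Amidine aryl swap in a DNA-binding oligoamide series

The source may hold more compounds than are shown below. What is called first, only, known or untested is meant among the compounds shown, and "the series" means these compounds.

Measured compounds:
- compound 1 `COc1cccc(C(=N)Nc2cc(C(=O)Nc3cc(C(=O)Nc4cc(C(=O)NCCCN(C)C)n(C)c4)n(C)c3)n(C)c2)c1` — 11 degrees C
- compound 2 `CC(C)CCc1sc(NC(=O)c2cc(NC(=O)c3cc(NC(=N)c4cccc(Cl)c4)cn3C)cn2C)nc1C(=O)NCCCN(C)C` — 5 degrees C

Two compounds have been run in an assay on nucleic acid for binding affinity to Salmon testes DNA (Salmonidae), tested at 10 uM; a lower number here means that the compound stabilises the target less, a higher number that the compound stabilises the target more against heat. Compound 1 gives 11 degrees C and stands highest of the two numbers. Compound 2 gives 5 degrees C, a lower figure that lies beyond the usual scatter; the two structures differ in several places at once, so nothing can be tied to a single change between them.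

Compound 3 `CN(C)CCCNC(=O)c1cc(NC(=O)c2cc(NC(=O)c3cc(NC(=N)c4cnc5ccccc5c4)cn3C)cn2C)cn1C` is not yet measured in this assay. It follows from compound 1 by one change: quinolin-3-yl in place of 3-methoxyphenyl on a carbon with a double bond to nitrogen. The rest of the shared core and the terminal chain are kept.

Among the compounds with values here, no measured pair shows what this particular swap does. The expectation rests on compound 1 alone, with its value of 11 degrees C as the anchor, and is that the shift moves little, in either direction, within or only just beyond the scatter. The step from compound 1 to compound 3 is expected to be a number 1.0 degrees C lower from compound 1 to compound 3 (within the scatter). Compound 3 is thus estimated at 10 degrees C, with a range from 6 degrees C to 14 degrees C.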

Compound 3, shift of the target's melting temperature: > 17 degrees C
Compound 3: no number, only a limit (the forecaster's own chance of this, stated with the estimate: 0%); middle value at least 7.0 degrees C away from the limit.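

In this assay, the aryl group on a carbon with a double bond to nitrogen proves to be a sensitive point in the series: with the rest of the structure kept, quinolin-3-yl in place of 3-methoxyphenyl gives a number at least 6.0 degrees C higher from compound 1 to compound 3 (beyond the scatter). Compound 3 gives > 17 degrees C, which is a limit of the assay and not a number. The step therefore fixes only a minimum size, and its true size stays unknown, with compound 3 the only one of the compounds shown that stands at this limit: the limit of > 17 degrees C in this assay, at which 1 of the 3 values shown sits.

The compounds shown leave open whether the step goes with the added ring of quinolin-3-yl or with its ring nitrogen, a question that naphthalen-2-yl and pyridin-3-yl on the same carbon would separate. Also open, on these data alone, is whether the swap carries over to another core, such as that of compound 2, which differs from compound 1 and compound 3 in several places and so gives no direct comparison with either.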